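A few compounds are considered here, and "the series" means these few. Any claim that something is new, unique, unknown or untested is made for them only; others in the source may bear on it.

Measured compounds:
Compound 1, `O=C(Nc1cccc(-n2cc(-c3ccncc3)c(-c3ccc(Cl)c(O)c3)n2)c1)Nc1cccc(C(F)(F)F)c1`: in a functional assay on MDA-MB-468 cells (Homo sapiens) for inhibition, read by sulforhodamine B assay, with a stated time of 48 h (on this read-out lower numbers stand for stronger inhibition and higher numbers for weaker inhibition), compound 1 gives 980 nM.
Compound 2, `O=C(Nc1cccc(-n2cc(-c3ccncc3)c(-c3ccc(Cl)c(O)c3)n2)c1)Nc1ccc(Cl)c(Cl)c1`: in this assay compound 2 gives 730 nM.
Compound 3, `COc1cc(-c2nn(-c3cccc(NC(=O)Nc4ccc(Cl)c(C(F)(F)F)c4)c3)cc2-c2ccncc2)ccc1Cl`: in this assay compound 3 gives 830 nM.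

Compound 3 stands second highest of the three numbers; its gaps to compound 2 and to compound 1 are both within the scatter, so the three measured compounds are not separated from one another. Compound 4, `O=C(Nc1cccc(-n2cc(-c3ccncc3)c(-c3ccc(Cl)c(O)c3)n2)c1)Nc1ccc(Cl)c(C(F)(F)F)c1`, is yet to be measured. It differs from compound 3 in one place: hydrogen in place of methyl on an oxygen on an aromatic ring. Among the measured compounds shown here, the only measured single-point step, a 1.3-fold lower number from compound 1 to compound 2 (0.13 log units; within the scatter), concerns a different part of the molecule, the substituent on the amide-type nitrogen, and lies within the scatter. For the measured compounds named here, no measured pair shows the methoxy to hydroxy change itself; what the series does show is that compounds 1 and 2, which already carry the hydroxy group, sit alongside compound 3 within the scatter. The expectation is therefore a step no larger than the scatter, in no particular direction: a 1.0-fold lower number from compound 3 to compound 4 (0.02 log units; within the scatter). For compound 4 the estimated value in this assay is 800 nM, with a range from 400 nM to 1600 nM.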

Compound 4, half-maximal inhibitory concentration: 540 nM
Compound 4: the middle estimate sits 1.5-fold (0.17 log units) above what was measured, within the range that was stated.
By their numbers in this assay, from the lowest: compounds 4, 2, 3 and 1 (each within the scatter of the next).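

In this assay, the methoxy to hydroxy change on the aromatic ring can now be read directly as a 1.5-fold lower number from compound 3 to compound 4 (0.19 log units; within the scatter), so methyl and hydrogen on this oxygen are not separated in this cell read-out, with the 4-chloro-3-methoxyphenyl and 4-chloro-3-hydroxyphenyl forms standing level within the scatter. With the 4-chloro-3-hydroxyphenyl group held constant, the substituent on the other aromatic ring also gives no separation, whether trifluoromethyl replaces chloro, as a 1.4-fold lower number from compound 2 to compound 4 (0.13 log units; within the scatter), or chloro replaces hydrogen, as a 1.8-fold lower number from compound 1 to compound 4 (0.26 log units; within the scatter). The compounds shown offer no independent data that could explain these readings.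

Open, on these data alone, is whether this tolerance extends beyond hydrogen and methyl on the oxygen, for example to an ethyl group or a longer chain, or whether an amine or a carboxylic acid in place of the hydroxy group would stay within the same range. Also open is whether the lack of separation among these four compounds would hold on another read-out, since all of the values here come from a single cell assay.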